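This account rests on a few compounds, and the source may have more. Where it says the series, first, only, none or still open, it means among the compounds named here.

In a functional assay on DU-145 cells (Homo sapiens) for antiproliferative activity, read by MTT assay, with a stated time of 72 h (on this read-out lower numbers stand for stronger inhibition and higher numbers for weaker inhibition), compound 1 `COc1cc2c(Nc3ccc(C#N)cc3)ncnc2cc1OCCCN1CCC(O)CC1` gives 74900 nM as its reading. Compound 2 `COc1cc2c(Nc3ccc(C#N)cc3)ncnc2cc1OCCCN1CCCCC1CCO` gives > 100000 nM, which is a limit of the assay and not a number. Compound 3 `COc1cc2c(Nc3ccc(C#N)cc3)ncnc2cc1OCCCN1CCC(N2CCCCC2)CC1` gives 15600 nM and so holds the lower of the two actual numbers. Compound 4 `CCN1CCN(CCCOc2cc3ncnc(Nc4ccc(C#N)cc4)c3cc2OC)CC1` differs from compound 3 at one place 4-ethylpiperazin-1-yl in place of 4-(piperidin-1-yl)piperidin-1-yl on a saturated chain carbon, three bonds along the chain from an oxygen on an aromatic ring and the rest of the structure stays the same. Both a 4.8-fold lower number from compound 1 to compound 3 (0.68 log units; beyond the scatter) and an at least 6.4-fold lower number from compound 2 to compound 3 (0.80 log units; beyond the scatter) came with the arrival of the 4-(piperidin-1-yl)piperidin-1-yl group, which compound 4 lacks. Neither step tested 4-ethylpiperazin-1-yl, so part of that gain may survive. A modest rise is therefore expected, estimated as a 2.2-fold higher number from compound 3 to compound 4 (0.35 log units; beyond the scatter) in this assay here. For compound 4 the estimated value is 35000 nM with an expected range of 10000 nM to 100000 nM.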

Compound 4, half-maximal inhibitory concentration: 34400 nM
Beside the measured number, compound 4's estimate is 1.0-fold (0.01 log units) above it, within the range that was stated.
By their numbers in this assay, from the lowest: compound 3; then compound 4; then compound 1. At a limit, above all of these: compound 2.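

The 4-ethylpiperazin-1-yl group keeps only part of the gain seen with 4-(piperidin-1-yl)piperidin-1-yl at this place on the chain: the swap gives a 2.2-fold higher number from compound 3 to compound 4 (0.34 log units; beyond the scatter), yet there is still a 2.2-fold lower number from compound 1 to compound 4 (0.34 log units; beyond the scatter). A single ring bearing two nitrogens is therefore enough for a lower number than compound 1 gives, without the second ring of compound 3. Against compound 2 there is an at least 2.9-fold lower number from compound 2 to compound 4 (0.46 log units; beyond the scatter), and that step rests on a limit, not a number: the limit of > 100000 nM in this assay, at which 1 of the 4 values shown sits.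

On these data alone, it remains open whether the ring nitrogen or the ethyl group matters more. A morpholin-4-yl or 4-methylpiperazin-1-yl group at this place would help separate the two.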